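The source may report more compounds than this note shows. Statements on the series, on what has been measured and on what is new or still open speak of the compounds shown alone.

Working notes on the series.

The two measured compounds share one core and differ only at the amine nitrogen in the ring at the far end. Compound 1 `CCCS(=O)(=O)N1CC=C(c2ccc3c(c2)CC(C2CCN(Cc4ccccc4)CC2)O3)CC1` carries a benzyl group there and in a functional assay on HEK293 cells for agonist activity at Glucose-dependent insulinotropic receptor (Homo sapiens), read by cAMP accumulation, with a stated time of 60 min (on this read-out lower numbers stand for an effect already at smaller amounts and higher numbers for an effect only at larger amounts of compound), compound 1 gives 521 nM. Compound 2 `CCCS(=O)(=O)N1CC=C(c2ccc3c(c2)CC(C2CCN(c4ncc(Cl)cn4)CC2)O3)CC1` carries a 5-chloropyrimidin-2-yl group instead; in this assay compound 2 gives 78 nM, the lowest of the two numbers, and the step of a 6.7-fold lower number from compound 1 to compound 2 (0.82 log units; beyond the scatter) lies beyond the scatter.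

The next compound to be measured is compound 3 `CCCS(=O)(=O)N1CC=C(c2ccc3c(c2)CC(C2CCN(c4ncc(C(F)(F)F)cn4)CC2)O3)CC1`. The change from compound 2 is trifluoromethyl in place of chloro on an aromatic carbon. For the measured compounds named here, no measured step touches this position: the only step seen, from compound 1 to compound 2, exchanges the whole group on the amine nitrogen, and says nothing about swapping one substituent for another on the 5-chloropyrimidin-2-yl ring itself. The expectation therefore rests on the size of the change alone, which is small, and no shift beyond the scatter is expected in either direction, so the step of a 1.1-fold lower number from compound 2 to compound 3 (0.05 log units; within the scatter) is estimated to be modest at most. For compound 3 in this assay the estimate is 70 nM, with a range from 25 nM to 200 nM.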

Compound 3, half-maximal effective concentration: 14 nM
For compound 3 the middle estimate is 5.0-fold (0.70 log units) above the measured one; the whole stated range lies above it.
By their numbers in this assay, from the lowest: compound 3; then compound 2; then compound 1.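

The position on the aromatic carbon para to a large group, on the six-membered aromatic ring with 2 nitrogen, is now shown to respond in this assay: a single-substituent change, trifluoromethyl in place of chloro, gives a 5.6-fold lower number from compound 2 to compound 3 (0.75 log units; beyond the scatter). Until now only the exchange of the whole group on the amine nitrogen had been seen, as a 6.7-fold lower number from compound 1 to compound 2 (0.82 log units; beyond the scatter), and that step could not show whether the substituent on the new ring mattered. With trifluoromethyl on that ring, the exchange of benzyl reaches a 37-fold lower number from compound 1 to compound 3 (1.57 log units; beyond the scatter), so the value of the exchange depends on which substituent the 5-substituted pyrimidin-2-yl group carries; nothing available bears on what lies behind the step from chloro to trifluoromethyl.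

On these data alone, two substituents at this position make no trend, so it remains open how a nitrile, a methyl, a methoxy or a pentafluoroethyl group would compare with trifluoromethyl there. As far as these compounds go, it is also open whether the same substituent change would give a similar step with a different chain on the sulfonyl group, such as ethyl or cyclopropyl in place of propyl.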